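This account rests on a few compounds, and the source may have more. Where it says the series, first, only, none or still open, it means among the compounds named here.

In an ADME assay on microsomes from liver (Rattus norvegicus) for metabolic stability, read by LC-MS, using NADPH, with a stated time of 30 min, tested at 1 uM (on this read-out lower numbers stand for a less stable compound and higher numbers for a more stable compound), compound 1 `C=CC(=O)Nc1cc(Nc2ncc(F)c(Nc3ccccc3S(=O)(=O)N(C)C)n2)c(OC)cc1N(C)CCN(C)C` gives 7% and compound 2 `C=CC(=O)Nc1cc(Nc2ncc(F)c(Nc3ccccc3S(=O)(=O)C(C)C)n2)c(OC)cc1N(C)CCN(C)C` gives 11%. Among the measured compounds shown here, these two values lie within the scatter of each other, so the numbers do not separate compound 2 from the only other compound measured. Compound 3 `C=CC(=O)Nc1cc(Nc2nccc(Nc3ccccc3S(=O)(=O)C(C)C)n2)c(OC)cc1N(C)CCN(C)C` differs from compound 2 by one change: hydrogen in place of fluoro on an aromatic carbon. For the measured compounds named here, the one measured step is a number 4 percentage points higher from compound 1 to compound 2 (within the scatter), with isopropyl in place of dimethylamino on a sulfonyl sulfur. Going by the values given here, it stays within the scatter but concerns a different change, and no measured step removes the fluoro, so the data give only an indirect guide. No step beyond the scatter is expected in this assay. The expected step is a number 1 percentage points lower from compound 2 to compound 3 (within the scatter). For compound 3 the estimated value is 10%, with an expected range of 3% to 22%.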

Compound 3, percent of the compound remaining: 22%
For compound 3 the middle estimate is 12 percentage points below the measured one; the measured number falls inside the stated range.
By their numbers in this assay, from the lowest: compounds 1 and 2 (each within the scatter of the next); then compound 3.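

In this assay, among the compounds shown here, the carbon that carries the fluoro, two atoms from the ring nitrogen, proves to be a place where a single change registers: hydrogen in place of fluoro gives a number 11 percentage points higher from compound 2 to compound 3 (beyond the scatter) and is the first step to separate two compounds. The earlier change on the sulfonyl sulfur, by contrast, gave a number 4 percentage points higher from compound 1 to compound 2 (within the scatter) and separated nothing. Nothing shown here accounts for why removing this one fluorine atom has this result.

The compounds shown leave open whether chloro, methyl or a nitrile on this same carbon would read closer to compound 2 or to compound 3. They also leave open whether hydrogen in place of fluoro gives a similar step when dimethylamino, rather than isopropyl, sits on the sulfonyl sulfur.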